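Compound 3 to compound 4: replacing the nitrophenyl group

The source may hold more compounds than are shown below. What is called first, only, known or untested is meant among the compounds shown, and "the series" means these compounds.

Measured in a functional assay (aorta) with Rattus norvegicus as the target; a lower number here means a stronger inhibitor, a higher number a weaker inhibitor:
- Compound 1 `CC1(C)Oc2ccc(C#N)cc2[C@@H](/N=C(\NC#N)Nc2ccccc2)[C@@H]1O`: 1400 nM; 1300 nM (2 entries)
- Compound 2 `CC1(C)Oc2ccc(C#N)cc2[C@@H](/N=C(\NC#N)NCc2ccccc2)[C@@H]1O`: 2400 nM
- Compound 3 `CC1(C)Oc2ccc(C#N)cc2[C@@H](/N=C(\NC#N)Nc2ccc([N+](=O)[O-])cc2)[C@@H]1O`: 300 nM

Repeat readings stay close: the several entries of compound 1 in this assay, 1400 nM; 1300 nM (2 entries). Within the data shown here, compound 3, at 300 nM, has the lowest number so far in this assay. Among the measured compounds shown here, the one measured step leading to it is an 8.0-fold lower number from compound 2 to compound 3 (0.90 log units; beyond the scatter).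

Next is compound 4 `CC1(C)Oc2ccc(C#N)cc2[C@@H](/N=C(\NC#N)Nc2cccc(C(=O)O)c2)[C@@H]1O`, with 3-carboxyphenyl in place of 4-nitrophenyl on an amine nitrogen. For the measured compounds named here, no measured compound carries 3-carboxyphenyl, so the evidence is indirect. The step from benzyl shows that this substituent can move the number well beyond the scatter. Without the nitro group, compound 1 gives 1400 nM; 1300 nM (2 entries), which also suggests that the low number of compound 3 may not survive the exchange.

A rise of about the same size as the measured step is therefore expected, in the opposite direction: an 8.3-fold higher number from compound 3 to compound 4 (0.92 log units; beyond the scatter) is the estimated change. For compound 4 the estimated value is 2500 nM, with an expected range of 600 nM to 12000 nM.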

Compound 4, half-maximal inhibitory concentration: > 100000 nM
Compound 4: only a limit was reported (the forecaster's own chance of this, stated with the estimate: 15%); at least 40-fold (1.60 log units) between middle value and limit.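

In this assay compound 4 gives > 100000 nM, which is a limit of the assay and not a number. Read against this limit, the exchange is an at least 330-fold higher number from compound 3 to compound 4 (2.52 log units; beyond the scatter), and the comparison with the benzyl compound is an at least 41-fold higher number from compound 2 to compound 4 (1.61 log units; beyond the scatter). The 4-nitrophenyl and 3-carboxyphenyl groups both have 9 heavy atoms and one six-membered aromatic ring, so a substituted phenyl on this amine nitrogen does not by itself carry the low number of compound 3, and the outcome here depends strongly on the substituent and where it sits.

Going by these compounds, the exchange alters both the substituent and its place on the phenyl ring, so the share of each stays open. A methyl ester or a primary amide in place of the carboxylic acid would show whether the free acid is what matters.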